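A few compounds are considered here, and "the series" means these few. Any claim that something is new, unique, unknown or untested is made for them only; others in the source may bear on it.

Values in a functional assay on HepG2 cells (Homo sapiens) for antiproliferative activity, read by MTT assay, with a stated time of 48 h (on this read-out lower numbers stand for stronger inhibition and higher numbers for weaker inhibition), for the measured compounds:

- compound 1 `Cc1ccc(-c2nc(NC(=O)c3ccccc3)c3cc(Cl)ccc3n2)cc1` gives 17.5 ug/mL
- compound 2 `CSc1nc(-c2ccc(C)cc2)nc2ccc(Cl)cc12` gives 13.3 ug/mL
- compound 3 `Cc1ccc(-c2nc(SCC#N)c3cc(Cl)ccc3n2)cc1` gives 4.37 ug/mL

Compound 3 has the lowest number of the three, and its gaps to both others lie beyond the scatter. Compound 4 `Cc1ccc(-c2nc(SCCO)c3cc(Cl)ccc3n2)cc1` carries hydroxymethyl in place of cyano on a saturated chain carbon bound to a sulfur. The closest evidence is a 3.0-fold lower number from compound 2 to compound 3 (0.48 log units; beyond the scatter) with cyano in place of hydrogen on that carbon, a modest step beyond the scatter. Going by the values given here, compound 4 loses that cyano, and no measured compound shows what hydroxymethyl does there. A partial return toward the number of compound 2 seems likely. The expected change is a 2.3-fold higher number from compound 3 to compound 4 (0.36 log units; beyond the scatter) as a modest estimated move toward weaker inhibition. The estimated value for compound 4 is 10 ug/mL with an expected range (4 ug/mL to 25 ug/mL).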

Compound 4, half-maximal inhibitory concentration: 9.04 ug/mL
Compound 4: the middle estimate sits 1.1-fold (0.04 log units) above what was measured; the measured number falls inside the stated range.
By their numbers in this assay, from the lowest: compound 3; then compounds 4, 2 and 1 (each within the scatter of the next).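

In this assay, hydroxymethyl in place of cyano on this chain carbon gives a 2.1-fold higher number from compound 3 to compound 4 (0.32 log units; beyond the scatter), so the cyano gain is not kept with this other two-heavy-atom group. Hydroxymethyl also does not separate compound 4 from its simpler relatives, with a 1.5-fold lower number from compound 2 to compound 4 (0.17 log units; within the scatter) and a 1.9-fold lower number from compound 1 to compound 4 (0.29 log units; within the scatter), which leaves cyano as the only one of the three groups on this carbon to stand apart. No measurement shown explains this difference. On these data alone, whether an amine, a carboxylic acid or a longer chain at this place would match cyano or hydroxymethyl stays open.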